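The source may hold more compounds than are shown below. What is called first, only, known or untested is meant among the compounds shown, and "the series" means these compounds.

Measured in a functional assay on MGC-803 cells (Homo sapiens) for inhibition, read by MTT assay, with a stated time of 48 h; on this read-out higher numbers stand for weaker inhibition and lower numbers for stronger inhibition:
- compound 1 `CCC/C=C/C(=O)N(Cc1ccc(OC)c(O)c1)c1cc(OC)c(OC)c(OC)c1`: 70 nM
- compound 2 `COc1ccc(CN(C(=O)CCl)c2cc(OC)c(OC)c(OC)c2)cc1O`: 84 nM
- compound 3 `C/C=C/C(=O)N(Cc1cc(OC)c(OC)c(OC)c1)c1ccc(OC)c(O)c1`: 6150 nM

Within the data shown here, compound 2 stands together with compound 1, the two numbers lying within the usual scatter of each other, and far from compound 3, whose number is very much higher; no single-point step links compound 2 and compound 3, so only the two values themselves can be compared.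

Compound 4 `C=C(C)C(=O)N(Cc1ccc(OC)c(O)c1)c1cc(OC)c(OC)c(OC)c1` has not yet been measured. It differs from compound 2 by 1-methylethenyl in place of chloromethyl on a carbonyl carbon. Among the measured compounds shown here, the one measured step that bears on this position is a 1.2-fold higher number from compound 1 to compound 2 (0.08 log units; within the scatter), which shows that exchanging the group on the carbonyl carbon between pent-1-en-1-yl and chloromethyl left the number essentially where it was. On that basis a further exchange at the same carbonyl carbon is expected to produce no step beyond the scatter in this assay, in either direction.

For compound 4 the expected value is therefore 100 nM (range 40 nM to 300 nM), which means an expected step of a 1.2-fold higher number from compound 2 to compound 4 (0.08 log units; within the scatter).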

Compound 4, half-maximal inhibitory concentration: 390 nM
Beside the measured number, compound 4's estimate is 3.9-fold (0.59 log units) below it; the whole stated range lies below it.
By their numbers in this assay, from the lowest: compounds 1 and 2 (each within the scatter of the next); then compound 4; then compound 3.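

In this assay the group on the carbonyl carbon turns out to matter: 1-methylethenyl gives a 4.6-fold higher number from compound 2 to compound 4 (0.67 log units; beyond the scatter), and against pent-1-en-1-yl the same group gives a 5.6-fold higher number from compound 1 to compound 4 (0.75 log units; beyond the scatter). Chloromethyl and pent-1-en-1-yl had read alike within the scatter, so this position accepts some exchanges without a change in the number but not every one, and the agreement of those two groups does not extend to all groups placed here. The data shown give no reason for the size of these steps.

Still open, as far as these compounds go, is how a methyl, a longer saturated chain or an amine on the same carbonyl carbon would read. Also open, from the compounds shown here alone, is whether any such group would fall with compound 1 and compound 2 or with compound 4.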